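The source may report more compounds than this note shows. Statements on the series, on what has been measured and on what is new or still open speak of the compounds shown alone.

Working notes on the series. Compound 2 `C#CCNC1CCc2c(OCCCCCN3CCN(c4cccc5c4ccn5Cc4cccc(Cl)c4)CC3)cccc21` gives 80% in an assay on BTI cells for inhibition of Amine oxidase [flavin-containing] B (Homo sapiens), read by fluorescence, with stated times of 30 min and 1 h, tested at 1 uM (a higher number here means more inhibition at the concentration tested (going by the name of the read-out), a lower number less inhibition), and stands highest of the three numbers measured. The nearest is compound 3 `C#CCNC1CCc2c(OCCCCN3CCN(c4cccc5c4ccn5S(=O)(=O)c4ccccc4)CC3)cccc21`, which in this assay gives 44%, a number beyond the scatter below compound 2. Furthest off is compound 1 `C#CCNC1CCc2c(OCCCN3CCN(c4cccc5c4ccn5Cc4cccc(Cl)c4)CC3)cccc21`, which in this assay gives 31%, also beyond the scatter below compound 2. Going by the values given here, none of these three pairs differs in one place only, so no single step is drawn among them; their values are taken as they stand.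

Compound 4 `C#CCNC1CCc2c(OCCCCCN3CCN(c4cccc5c4ccn5S(=O)(=O)c4ccccc4)CC3)cccc21` has not yet been measured. It is derived from compound 2 by phenylsulfonyl in place of 3-chlorobenzyl on an aromatic nitrogen. Compound 3 carries the same phenylsulfonyl on its aromatic nitrogen and is otherwise close to compound 4, and compound 3 sits well below compound 2. On that basis the step from compound 2 to compound 4 in this assay is expected to go downward and beyond the scatter, though less far than the gap between compound 2 and compound 3, since compound 4 keeps the chain of compound 2. The expected step is a number 25 percentage points lower from compound 2 to compound 4 (beyond the scatter). Compound 4 is accordingly estimated at 55% in this assay, within a range from 32% to 76%.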

Compound 4, a percentage reported as inhibition, at one concentration (the size of the read-out at that concentration, not a potency): 90%
The estimate for compound 4 lay 35 percentage points below the measured number; the measured number lies above the stated range.
By their numbers in this assay, from the lowest: compound 1; then compound 3; then compounds 2 and 4 (each within the scatter of the next).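

On the aromatic nitrogen of the five-membered aromatic ring, phenylsulfonyl in place of 3-chlorobenzyl gives a number 10 percentage points higher from compound 2 to compound 4 (within the scatter) in this assay, so with the chain of compound 2 this position does not separate the two groups, even though only the entering group carries hydrogen-bond acceptors. The phenylsulfonyl group is therefore compatible with a high number on this nitrogen: compound 4 gives 90% in this assay and compound 3, with the same group on a different chain, gives 44% there, so the group alone does not fix the reading. No measurement at hand explains why the two groups read alike.

From the compounds shown here alone, whether an unsubstituted benzyl, a methanesulfonyl or an acetyl on the same nitrogen would read like these two groups stays open, as does the effect of a longer chain carrying phenylsulfonyl or 3-chlorobenzyl. Going by these compounds, a reading at one concentration is not a potency, so whether compound 2 and compound 4 would still read alike at lower concentrations also stays open.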